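Ammonium head-group swap on two phenoxy cores

The source may hold more compounds than are shown below. What is called first, only, known or untested is meant among the compounds shown, and "the series" means these compounds.

The series shares one core and varies the charged head at the end of the alkoxy chain. Compound 1 `CC[N+]1(CCCCCCCOc2ccc(-n3cc(C(=O)Nc4cc(F)cc(F)c4)c(=O)c4ccc(N(C)C)nc43)cc2Cl)CCCC1` carries a chlorinated ring and gives 23.5% in an assay on LX2 cells for inhibition of COL1A1 promoter (Homo sapiens), read by a luciferase reporter, with a stated time of 24 h, tested at 50 uM; a higher number here means a stronger effect of the compound at the concentration tested, a lower number a weaker effect. Compound 3 `CN(C)c1ccc2c(=O)c(C(=O)Nc3cc(F)cc(F)c3)cn(-c3ccc(OCCCCCCC[N+](C)(C)C4CCCCC4)c(Cl)c3)c2n1` keeps that ring and exchanges the head group; in this assay compound 3 gives 86.2%. The change is a group of 9 heavy atoms (8 carbon, 1 nitrogen; one six-membered non-aromatic ring of carbon only) in place of a group of 7 heavy atoms (6 carbon, 1 nitrogen; one five-membered non-aromatic ring with 1 hetero atom), on a saturated chain carbon, seven bonds along the chain from an oxygen on an aromatic ring and the step it made is a number 62.7 percentage points higher from compound 1 to compound 3 (beyond the scatter).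

Compound 2 `CC[N+]1(CCCCCCCOc2cc(C)cc(-n3cc(C(=O)Nc4cc(F)cc(F)c4)c(=O)c4ccc(N(C)C)nc43)c2)CCCC1` has a methyl-bearing ring in place of the chlorinated one, with the same head group as compound 1; in this assay compound 2 gives 73.2%. The difference between the cores of compound 1 and compound 2 is not broken down here; their two values simply show compound 2 well above compound 1 and somewhat below compound 3.

Compound 4 `Cc1cc(OCCCCCCC[N+](C)(C)C2CCCCC2)cc(-n2cc(C(=O)Nc3cc(F)cc(F)c3)c(=O)c3ccc(N(C)C)nc32)c1` is not yet measured. It relates to compound 2 as compound 3 relates to compound 1: the change is a group of 9 heavy atoms (8 carbon, 1 nitrogen; one six-membered non-aromatic ring of carbon only) in place of a group of 7 heavy atoms (6 carbon, 1 nitrogen; one five-membered non-aromatic ring with 1 hetero atom), on a saturated chain carbon, seven bonds along the chain from an oxygen on an aromatic ring, and the place is the same word for word, so this is the same change on the other core. Because compound 1 to compound 3 moved by a number 62.7 percentage points higher from compound 1 to compound 3 (beyond the scatter), an upward step is expected from compound 2 to compound 4, but compound 2 already sits high, and a percentage read-out cannot rise far past full inhibition, so the expected step of a number 15.8 percentage points higher from compound 2 to compound 4 (beyond the scatter) is smaller than the earlier one. Compound 4 is estimated at 89%, with an expected range from 76% to 98%.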

Compound 4, a percentage reported as inhibition, at one concentration (the size of the read-out at that concentration, not a potency): 89.1%
The estimate for compound 4 lay 0.1 percentage points below the measured number; the range from low to high includes it.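

In this assay, the six-membered carbon ring head in place of the five-membered ring head gives a gain on the second core too, the new step being a number 15.9 percentage points higher from compound 2 to compound 4 (beyond the scatter), so the direction of the change carries over on the two cores shown. The size of the change does not carry over, and a step read on one of these cores cannot be transferred as a number to the other: the same change on two cores in this assay, a number 62.7 percentage points higher (beyond the scatter) from compound 1 to compound 3 and a number 15.9 percentage points higher (beyond the scatter) from compound 2 to compound 4, 46.8 percentage points apart, beyond the scatter of two such steps

Among the compounds shown here, with only two cores, these numbers cannot separate an effect of the core itself from an effect of the starting value, since compound 1 starts at 23.5% and compound 2 at 73.2%, and a read-out at a single concentration gives no potency for any of the compounds.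

Still open, as far as these compounds go, is whether the same direction would hold on a third core, for example one carrying a methoxy group or a fluorine in place of the methyl or the chlorine. Also open, from the compounds shown here alone, is how the head-group change would behave with a shorter or longer chain, or with a neutral tertiary amine or a piperidine-based ammonium as the head.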